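Piperazin-1-yl for pyridin-4-yl on the shared core

A few compounds are considered here, and "the series" means these few. Any claim that something is new, unique, unknown or untested is made for them only; others in the source may bear on it.

- Compound 1 `COc1ccc(-c2cc(C(=O)N3CCC4(CC3)CC(=O)c3nn(C(C)(C)C)cc3O4)c3ccccc3n2)cc1OC`: 2030 nM
- Compound 2 `CC(C)(C)n1cc2c(n1)C(=O)CC1(CCN(C(=O)c3cc(-c4ccncc4)nc4ccccc34)CC1)O2`: 550 nM

In a functional assay on A549 cells (Homo sapiens) for inhibition, read by MTT assay, with a stated time of 72 h (a lower number here means a stronger inhibitor, a higher number a weaker inhibitor), compound 2 has the lower of the two values, at 550 nM. Compound 3 `CC(C)(C)n1cc2c(n1)C(=O)CC1(CCN(C(=O)c3cc(N4CCNCC4)nc4ccccc34)CC1)O2` carries piperazin-1-yl in place of pyridin-4-yl on an aromatic carbon. Within the data shown here, the only measured step at this carbon is a 3.7-fold lower number from compound 1 to compound 2 (0.57 log units; beyond the scatter), where pyridin-4-yl replaced 3,4-dimethoxyphenyl. Among the measured compounds shown here, no measured compound has a non-aromatic ring there, so that step indicates size only and direction stays uncertain. The expected change is a 1.8-fold higher number from compound 2 to compound 3 (0.26 log units; within the scatter), of modest size. For compound 3 the estimate is 1000 nM, with an expected range of 250 nM to 4000 nM.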

Compound 3, half-maximal inhibitory concentration: > 10000 nM
Compound 3 was reported as a limit; the forecaster's own chance of this, stated with the estimate: 5%; middle value at least 10-fold (1.00 log units) from the limit.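

Compound 3, with piperazin-1-yl on this carbon, gives a limit and not a number: the limit of > 10000 nM in this assay, at which 1 of the 3 values shown sits.

The change from pyridin-4-yl is an at least 18-fold higher number from compound 2 to compound 3 (1.25 log units; beyond the scatter), and the change from 3,4-dimethoxyphenyl is an at least 4.9-fold higher number from compound 1 to compound 3 (0.69 log units; beyond the scatter). This carbon is therefore not indifferent to its group: both aromatic rings shown give lower numbers than this non-aromatic ring.

Going by these compounds, the full size of the loss stays open behind the limit. Also open, on these data alone, is whether the loss follows the non-aromatic ring or its amine hydrogen, which a morpholine ring or a methyl group on the piperazine nitrogen could separate.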